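Hydroxyphenyl Placement and Cytotoxicity in Prostate Cancer Cells

A few compounds are considered here, and "the series" means these few. Any claim that something is new, unique, unknown or untested is made for them only; others in the source may bear on it.

compound 1, `Oc1ccc(-c2cc(-c3cccc(O)c3)nc(-c3cccc(O)c3)c2)cc1`: 1760 nM
compound 2, `Oc1ccccc1-c1cc(-c2ccccc2O)nc(-c2ccccc2O)c1`: 5040 nM
compound 3, `Oc1ccc(-c2cc(-c3cccc(O)c3)cc(-c3ccc(O)cc3)n2)cc1`: 1400 nM

These three compounds were tested in a functional assay on DU-145 cells (Homo sapiens) for cytotoxicity, read by CCK-8 assay, with a stated time of 4 days; on this read-out higher numbers stand for weaker inhibition and lower numbers for stronger inhibition. Compound 1 stands second highest of the three numbers. Compound 3 is nearest to it, with a number lower by a margin that lies within the scatter, so the two cannot be ranked against each other. Compound 2 is furthest, with a number higher by a margin beyond the scatter, so compound 2 inhibits the cells less than compound 1 does.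

Compound 4, `Oc1cccc(-c2cc(-c3cccc(O)c3)nc(-c3cccc(O)c3)c2)c1`, has not yet been measured in this assay. It differs from compound 1 in a single place: 3-hydroxyphenyl in place of 4-hydroxyphenyl on an aromatic carbon. Going by the values given here, no measured pair shows this change directly. Compound 1 and compound 3, which both carry a mixture of 3-hydroxyphenyl and 4-hydroxyphenyl groups on the shared core, lie within the scatter of each other, and only compound 2, with a different arrangement of all three hydroxyl groups, falls beyond it. On that basis the step from compound 1 to compound 4 is expected to be a 1.1-fold lower number from compound 1 to compound 4 (0.04 log units; within the scatter), none beyond the scatter. Compound 4 is therefore estimated at 1600 nM, with a range from 600 nM to 4500 nM.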

Compound 4, half-maximal inhibitory concentration: 4040 nM
Beside the measured number, compound 4's estimate is 2.5-fold (0.40 log units) below it; measured number inside the range.
By their numbers in this assay, from the lowest: compounds 3 and 1 (each within the scatter of the next); then compounds 4 and 2 (each within the scatter of the next).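

In this assay, going by these compounds alone, replacing 4-hydroxyphenyl with 3-hydroxyphenyl on the aromatic carbon opposite the ring nitrogen gives a 2.3-fold higher number from compound 1 to compound 4 (0.36 log units; beyond the scatter), the first comparison here between compounds that differ in one place. The group that leaves and the group that enters have the same atoms, so the step shows that this position responds to where the hydroxyl stands on its phenyl ring, with weaker inhibition for 3-hydroxyphenyl than for 4-hydroxyphenyl, although the size of the step is modest. Nothing at hand accounts for this difference.

The step is read only with two 3-hydroxyphenyl groups elsewhere on the shared core, so the compounds shown leave open whether the same change would carry the same weight with other groups at those positions. They also leave open whether the hydroxyl itself matters at the position opposite the ring nitrogen, a question that a 4-methoxyphenyl or 4-aminophenyl group there could address.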